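The source may report more compounds than this note shows. Statements on the series, on what has been measured and on what is new or still open speak of the compounds shown alone.

Compound 1 `Cc1cc(F)ccc1S(=O)(=O)N1CCN(c2ccc(C(=O)NCc3ccc(F)cc3)nn2)CC1` is followed in an ADME assay on microsomes from liver (Mus musculus) for metabolic stability, read by LC-MS, using NADPH, tested at 10 uM (on this read-out higher numbers stand for a longer-lived compound and lower numbers for a shorter-lived compound), alongside compound 2 `N#Cc1ncccc1S(=O)(=O)N1CCN(c2ccc(C(=O)NCc3ccc(F)cc3)[n+]([O-])n2)CC1` and compound 3 `O=C(NCc1ccccc1)c1ccc(N2CCN(S(=O)(=O)c3ccccc3Cl)CC2)nn1`. In this assay compound 1 gives 0.25 h, the second highest of the three numbers; compound 2 gives 0.267 h, a value within the scatter of compound 1, while compound 3 gives 0.0333 h, the lowest of the set and beyond the scatter from compound 1. Compound 4 `Cc1nc(C(F)(F)F)ccc1S(=O)(=O)N1CCN(c2ccc(C(=O)NCc3ccc(F)cc3)nn2)CC1` is not yet measured. It differs from compound 1 in one place: 2-methyl-6-(trifluoromethyl)pyridin-3-yl in place of 4-fluoro-2-methylphenyl on a sulfonyl sulfur. Within the data shown here, no measured pair shows this change, so the size of its step is open. A modest step, not clearly beyond the scatter, is expected, with the half-life of compound 4 estimated at 0.35 h (range 0.12 h to 1 h), that is, a step of a 1.4-fold higher number from compound 1 to compound 4 (0.15 log units; within the scatter).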

Compound 4, half-life: 0.383 h
Estimate against measurement, compound 4: 1.1-fold (0.04 log units) below; the measured number falls inside the stated range.
By their numbers in this assay, from the lowest: compound 3; then compounds 1, 2 and 4 (each within the scatter of the next).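

In this assay, 2-methyl-6-(trifluoromethyl)pyridin-3-yl in place of 4-fluoro-2-methylphenyl on a sulfonyl sulfur gives a 1.5-fold higher number from compound 1 to compound 4 (0.19 log units; within the scatter). This position therefore accepts a ring with a hetero atom and more heavy atoms with no step beyond the scatter, although the reading rests on this single pair. Nothing available gives a reason for this result.

Open, as far as these compounds go, is whether an amine or a carboxylic acid on this ring would give a step beyond the scatter. Also open, from the compounds shown here alone, is whether this change gives a similar step on a different core.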